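The compounds below may be only part of what the source reports. "The series", "measured", "known", "first", "only" and "open" are said of these compounds alone.

Measured so far:
compound 1 `CCCCc1ccc(CN)c(=O)n1Cc1ccc(-c2ccccc2-c2nn[nH]n2)cc1`: 20 nM
compound 2 `CCCCc1ccc(CNC(=O)Nc2ccccc2)c(=O)n1Cc1ccc(-c2ccccc2-c2nn[nH]n2)cc1`: 30 nM
compound 3 `CCCCc1ccc(CNS(=O)(=O)c2ccc(C)cc2)c(=O)n1Cc1ccc(-c2ccccc2-c2nn[nH]n2)cc1`: 9 nM

In a functional assay (aorta) for antagonist activity, with Oryctolagus cuniculus as the target (a higher number here means a weaker inhibitor, a lower number a stronger inhibitor), compound 1 gives 20 nM, compound 2 gives 30 nM and compound 3 gives 9 nM. Compound 2 stands at the highest of the three numbers: the step of a 1.5-fold higher number from compound 1 to compound 2 (0.18 log units; within the scatter) is within the scatter, whereas a 3.3-fold lower number from compound 2 to compound 3 (0.52 log units; beyond the scatter) and a 2.2-fold lower number from compound 1 to compound 3 (0.35 log units; beyond the scatter) are both beyond it, modest in size.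

Compound 4 `CCCCc1ccc(CN(Cc2ccccc2)S(C)(=O)=O)c(=O)n1Cc1ccc(-c2ccccc2-c2nn[nH]n2)cc1` is not yet measured. The change from compound 2 is benzyl(methylsulfonyl)amino in place of (phenylcarbamoyl)amino on a saturated chain carbon bound to an aromatic carbon. Within the data shown here, the only measured step that bears on it is a 3.3-fold lower number from compound 2 to compound 3 (0.52 log units; beyond the scatter), where a sulfonyl group on that nitrogen in place of phenylcarbamoyl gave a modestly lower number. Among the measured compounds shown here, compound 4 likewise carries a sulfonyl on that nitrogen, but a methylsulfonyl, with the aromatic ring now on a benzyl attached to the same nitrogen and no hydrogen-bond donor left; none of the measured compounds carries such a group, so the expectation is loosely grounded.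

A modest move toward a lower number is expected for compound 4, a 2.0-fold lower number from compound 2 to compound 4 (0.30 log units; within the scatter), with a wide range. The estimate for compound 4 in this assay is 15 nM, between 5 nM and 45 nM.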

Compound 4, half-maximal inhibitory concentration: 2 nM
The estimate for compound 4 lay 7.5-fold (0.88 log units) above the measured number; the whole stated range lies above it.
By their numbers in this assay, from the lowest: compound 4; then compound 3; then compounds 1 and 2 (each within the scatter of the next).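

Working notes on the substituent on the saturated chain carbon bound to an aromatic carbon: in this assay, benzyl(methylsulfonyl)amino is the first group to stand clearly apart from all the others at this position, with steps beyond the scatter against (phenylcarbamoyl)amino (a 15-fold lower number from compound 2 to compound 4 (1.18 log units; beyond the scatter)), amino (a 10-fold lower number from compound 1 to compound 4 (1.00 log units; beyond the scatter)) and ((4-methylphenyl)sulfonyl)amino (a 4.5-fold lower number from compound 3 to compound 4 (0.65 log units; beyond the scatter)). The position therefore carries a much wider span than the first three compounds showed, and compound 4, the only one with no hydrogen left on that nitrogen, gives the lowest number, though a single compound does not establish a trend. No measurement bears on why this group gives the lowest number.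

Compound 4 differs from compound 3 in both the sulfonyl group and the benzyl on the nitrogen, so the compounds shown do not separate the contribution of each. Open questions are whether a methyl in place of the benzyl, or an acetyl in place of the methylsulfonyl, on the same nitrogen would keep the number this low.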